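This account rests on a few compounds, and the source may have more. Where it says the series, first, only, none or still open, it means among the compounds named here.

Measured in a functional assay on A-375 cells (Homo sapiens) for inhibition, read by MTT assay, with a stated time of 5 days; on this read-out lower numbers stand for stronger inhibition and higher numbers for weaker inhibition:
- compound 1 `Nc1nccc(-c2sc(C3CCCCN3)nc2-c2cccc(NS(=O)(=O)c3cc(F)ccc3F)c2F)n1`: 5.12 nM
- compound 2 `Nc1nccc(-c2sc(C3COCCN3)nc2-c2cc(Cl)cc(NS(=O)(=O)c3cc(F)ccc3F)c2F)n1`: 2.06 nM

Compound 1 has the higher of the two numbers, and the gap to compound 2 lies beyond the scatter. Compound 2 differs from compound 1 in more than one place, so this gap does not isolate any single change.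

Compound 3 `Nc1nccc(-c2sc(C3CCCNC3)nc2-c2cccc(NS(=O)(=O)c3cc(F)ccc3F)c2F)n1` is not yet measured. It carries piperidin-3-yl in place of piperidin-2-yl on an aromatic carbon of the shared core: piperidin-3-yl in place of piperidin-2-yl on an aromatic carbon. Going by the values given here, no measured pair shows what this kind of change does, so the expectation rests on compound 1 at 5.12 nM. No step beyond the scatter is expected in this assay, and the estimated step is a 1.4-fold higher number from compound 1 to compound 3 (0.14 log units; within the scatter). For compound 3 the estimated value is 7 nM, with an expected range from 2 nM to 25 nM.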

Compound 3, half-maximal inhibitory concentration: 44.1 nM
Compound 3: middle estimate off by 6.3-fold (0.80 log units), on the low side, and the stated range ends below it.
By their numbers in this assay, from the lowest: compound 2; then compound 1; then compound 3.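

In this assay, going by these compounds alone, the change from piperidin-2-yl to piperidin-3-yl on this aromatic carbon of the shared core gives an 8.6-fold higher number from compound 1 to compound 3 (0.94 log units; beyond the scatter), the first single-place step. The two groups have the same heavy atoms and the same counts of hydrogen-bond donors and acceptors, so this position responds to how the ring is joined to the core, even with composition unchanged. Nothing measured on these compounds bears on the reason for this step.

The compounds shown leave open how piperidin-4-yl, pyrrolidin-2-yl or an open-chain aminomethyl group would read at this carbon. They also leave open whether a step of this size would recur on the chlorine-bearing core of compound 2.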